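Swapping One Aromatic Ring for Another on the Shared Core

This account rests on a few compounds, and the source may have more. Where it says the series, first, only, none or still open, it means among the compounds named here.

Measured compounds:
compound 1, `Cc1ccc(-c2nc(CNc3ccc(C(=O)NO)cc3)n(-c3ccccc3)n2)cc1`: 62.2%
compound 2, `O=C(NO)c1ccc(NCc2nc(-c3ccccc3)nn2-c2ccc(C(F)(F)F)cc2)cc1`: 38.9%

Both compounds were tested in an assay on Sf9 cells for inhibition of protein deacetylase HDAC6 (Homo sapiens), read by fluorescence, with a stated time of 40 min, tested at 100 nM; a higher number here means more inhibition at the concentration tested (going by the name of the read-out), a lower number less inhibition. Compound 1 gives 62.2%, the higher of the two numbers; compound 2 gives 38.9%, and the gap between them lies beyond the scatter. Within the data shown here, no single-point change links compound 1 and compound 2, so their two values show only that compound 1 inhibits more at the tested concentration.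

Compound 3, `O=C(NO)c1ccc(NCc2nc(-c3ccncc3)nn2-c2ccccc2)cc1`, has not yet been measured in this assay. It differs from compound 1 in one place: pyridin-4-yl in place of 4-methylphenyl on an aromatic carbon. One six-membered aromatic ring gives way to another on the aromatic carbon between two ring nitrogen atoms of the shared core. Among the measured compounds shown here, no measured pair shows what such a swap does here. The step is estimated to be small and downward, a number 10.2 percentage points lower from compound 1 to compound 3 (beyond the scatter), and may well sit within the scatter. Compound 3 is estimated at 52%, within a range from 28% to 74%.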

Compound 3, a percentage reported as inhibition, at one concentration (the size of the read-out at that concentration, not a potency): 30.8%
Estimate against measurement, compound 3: 21.2 percentage points above; measured number inside the range.
By their numbers in this assay, from the lowest: compounds 3 and 2 (each within the scatter of the next); then compound 1.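

Among these compounds, this is the first measured step at the aromatic carbon between two ring nitrogen atoms of the shared core. In this assay, pyridin-4-yl in place of 4-methylphenyl gives a number 31.4 percentage points lower from compound 1 to compound 3 (beyond the scatter) and counts as a large change. The position therefore does not accept these two six-membered aromatic rings alike, and the choice of ring here clearly matters for inhibition at the tested concentration.

Two differences travel together in this swap, the ring nitrogen that enters and the methyl group that leaves, and the pair cannot separate them; an unsubstituted phenyl group or pyridin-3-yl on the same carbon would bear on that question. Nothing at hand offers a measured reason for the drop.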